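The source may hold more compounds than are shown below. What is called first, only, known or untested is meant among the compounds shown, and "the series" means these compounds.

Compound 1 `O=C1CC(c2ccccc2)n2ncnc2N1`: 51.9 mg/kg
Compound 2 `O=C1CC(c2ccccc2F)n2ncnc2N1`: 31.7 mg/kg

In a functional assay on the whole organism (strain Kunming) with Mus musculus as the target (on this read-out higher numbers stand for an effect only at larger amounts of compound and lower numbers for an effect already at smaller amounts), compound 1 gives 51.9 mg/kg, the highest of the two numbers measured. In this assay compound 2 gives 31.7 mg/kg. The step between them is a 1.6-fold lower number from compound 1 to compound 2 (0.21 log units; within the scatter), so the two values cannot be told apart with confidence.

Compound 3 `O=C1CC(c2cccc(C(F)(F)F)c2)n2ncnc2N1` has not yet been measured. It differs from compound 1 by trifluoromethyl in place of hydrogen on an aromatic carbon. Going by the values given here, the only measured step that bears on this change is the one to compound 2, a 1.6-fold lower number from compound 1 to compound 2 (0.21 log units; within the scatter), where a fluoro also replaced a hydrogen on the same ring and the number hardly moved. Among the compounds with values here, no measured compound carries a trifluoromethyl, so there is nothing here that shows what that group does. The step expected is therefore a 1.4-fold lower number from compound 1 to compound 3 (0.14 log units; within the scatter), staying close to the scatter. Compound 3 is estimated at 38 mg/kg, within a range from 15 mg/kg to 90 mg/kg.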

Compound 3, dose for half-maximal effect: 54.8 mg/kg
For compound 3 the middle estimate is 1.4-fold (0.16 log units) below the measured one, within the range that was stated.
By their numbers in this assay, from the lowest: compounds 2, 1 and 3 (each within the scatter of the next).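

In this assay, placing trifluoromethyl in place of hydrogen on an aromatic carbon, meta to a large group, gives a 1.1-fold higher number from compound 1 to compound 3 (0.02 log units; within the scatter). Until this result, fluoro in compound 2 was the only group shown on this ring, so it is new that a substituent this much larger than hydrogen can sit at this position of compound 3 without moving the number beyond the scatter. Nothing available explains this outcome.

The compounds shown leave open whether an amine or a carboxylic acid on this same carbon would also stay within the scatter of compound 1. They also leave open whether a longer chain here would do the same.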